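The compounds below may be only part of what the source reports. "The series", "measured", "known", "first", "only" and "open" are said of these compounds alone.

Compound 2 `COc1c(NS(=O)(=O)c2ccc(F)cc2)cc(-c2ccc3nc(NC(=O)C4CC4)sc3n2)cc1C(N)=O` gives 2500 nM in a functional assay on HCT-116 cells (Homo sapiens) for antiproliferative activity, read by MTT assay, with a stated time of 72 h (on this read-out higher numbers stand for weaker inhibition and lower numbers for stronger inhibition), the lowest of the two numbers shown. Compound 1 `COc1c(NS(=O)(=O)c2ccc(F)cc2)cc(-c2ccc3nc(NC4CC4)sc3n2)cc1C(N)=O` gives 35700 nM in this assay, and the step of a 14-fold lower number from compound 1 to compound 2 (1.15 log units; beyond the scatter) is the only measured one. Compound 3 `NC(=O)c1cc(NS(=O)(=O)c2ccc(F)cc2)cc(-c2ccc3nc(NC(=O)C4CC4)sc3c2)c1` gives > 50000 nM in this assay, which is a limit of the assay and not a number. Compound 4 `COc1c(NS(=O)(=O)c2ccc(F)cc2)cc(-c2ccc3nc(NC(C)=O)sc3n2)cc1C(N)=O` differs from compound 2 by methyl in place of cyclopropyl on a carbonyl carbon. Within the data shown here, the measured step concerns the carbonyl, which compound 4 keeps; no measured step touches the group on that carbonyl. Compound 4 is therefore expected to stay close to compound 2, with a step of a 1.6-fold higher number from compound 2 to compound 4 (0.20 log units; within the scatter) that need not exceed the scatter. The value of compound 4 in this assay is estimated at 4000 nM, within a range from 1200 nM to 13000 nM.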

Compound 4, half-maximal inhibitory concentration: 4250 nM
Compound 4: middle estimate off by 1.1-fold (0.03 log units), on the low side; the measured number falls inside the stated range.
By their numbers in this assay, from the lowest: compounds 2 and 4 (each within the scatter of the next); then compound 1. At a limit, above all of these: compound 3.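

In this assay, methyl can stand in place of cyclopropyl on the carbonyl carbon with no change beyond the scatter (a 1.7-fold higher number from compound 2 to compound 4 (0.23 log units; within the scatter)). The cyclopropyl ring is therefore not required for the drop seen with the carbonyl, and acetyl in place of cyclopropyl on the nitrogen also gives a step beyond the scatter (an 8.4-fold lower number from compound 1 to compound 4 (0.92 log units; beyond the scatter)). Nothing given here accounts for either step. As far as these compounds go, whether a longer chain, a phenyl ring or an amine on that carbonyl carbon would hold this level remains open.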